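From compound 2 to compound 3: the sulfonyl substituent

The source may hold more compounds than are shown below. What is called first, only, known or untested is meant among the compounds shown, and "the series" means these compounds.

In an ADME assay on microsomes from liver (Homo sapiens) for pharmacokinetics, read by LC-MS, with a stated time of 60 min, tested at 1 uM (a lower number here means slower removal, a higher number faster removal of the compound), compound 1 `O=C(NCc1cccnc1)Nc1ccc(S(=O)(=O)N2CCC3(CCNC3)CC2)cc1` gives 4 mL/min/kg and compound 2 `CC1CCN(S(=O)(=O)c2ccc(NC(=O)NCc3cccnc3)cc2)CCN1` gives 5 mL/min/kg. These two numbers lie within the scatter of each other, so compound 2 stands level with compound 1 and the pair cannot be ranked. Compound 3 `N[C@H]1CC[C@H](NS(=O)(=O)c2ccc(NC(=O)NCc3cccnc3)cc2)CC1` has not yet been measured. The change to it is a group of 8 heavy atoms (6 carbon, 2 nitrogen; one six-membered non-aromatic ring of carbon only) in place of a group of 8 heavy atoms (6 carbon, 2 nitrogen; one seven-membered non-aromatic ring with 2 hetero atoms), on a sulfonyl sulfur: the seven-membered ring with 2 hetero atoms leaves, and (4-aminocyclohexyl)amino, with 2 defined stereocentres, enters. Going by the values given here, only one measured step bears on this change, and it also exchanges the group on the sulfonyl sulfur. That step, a 1.3-fold higher number from compound 1 to compound 2 (0.10 log units; within the scatter), gives no sign that such exchanges move the number in this assay. It is thin evidence, since neither measured compound carries a ring of carbon only. No step beyond the scatter is therefore expected, and no direction is favoured. The expected change is a 1.2-fold higher number from compound 2 to compound 3 (0.08 log units; within the scatter). For compound 3 the estimated clearance is 6 mL/min/kg, with an expected range of 3 mL/min/kg to 12 mL/min/kg.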

Compound 3, clearance: 5 mL/min/kg
For compound 3 the middle estimate is 1.2-fold (0.08 log units) above the measured one, and the stated range covers the measured number.
By their numbers in this assay, from the lowest: compounds 1, 2 and 3 (each within the scatter of the next).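

Working notes on the sulfonyl substituent: with (4-aminocyclohexyl)amino on the sulfonyl sulfur, this assay shows no change at the digits printed from compound 2 to compound 3 (within the scatter), and the comparison with the spiro-containing compound shows a 1.3-fold higher number from compound 1 to compound 3 (0.10 log units; within the scatter). The earlier pair carried only rings with hetero atoms at this place, whereas compound 3 extends the set to a six-membered ring of carbon only, and the three compounds still cannot be ranked in this read-out. No measurement at hand offers an account of this flat result.

As far as these compounds go, it remains open whether the same picture holds for a sulfonyl substituent with no amine at all, for example a carboxylic acid in place of the free amine of (4-aminocyclohexyl)amino, or a simple open alkyl chain on the sulfonamide nitrogen. The other stereoisomer of (4-aminocyclohexyl)amino also stays open, as the compounds shown carry only the one defined arrangement, so nothing here separates the contribution of that arrangement from that of the ring of carbon only.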